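The compounds below may be only part of what the source reports. "The series", "measured", "known", "first", "only" and "open" are said of these compounds alone.

Compound 1 `CCCC(=O)NCC1CCCc2ccc(OC)cc21` and compound 2 `CCCC(=O)NCC1CCCCc2ccc(OC)cc21` carry the same (propylcarbonyl)amino side chain on different cores; the difference between the two cores is not broken down here. In an assay for binding affinity to melatonin receptor type 1B (Gallus gallus), read by radioligand binding (a higher number here means a weaker inhibitor, a lower number a stronger inhibitor), compound 1 gives 0.45 nM, and compound 2 gives 1 nM. Compound 3 `COc1ccc2c(c1)C(CNC(C)=O)CCC2` keeps the core of compound 1 and differs from it by hydrogen in place of ethyl on a saturated chain carbon bound to a carbonyl carbon; in this assay compound 3 gives 4 nM, a step of an 8.9-fold higher number from compound 1 to compound 3 (0.95 log units; beyond the scatter). Compound 4 `COc1ccc2c(c1)C(CNC(C)=O)CCCC2` is not yet measured. It stands to compound 2 as compound 3 stands to compound 1, through (hydrogen in place of ethyl on a saturated chain carbon bound to a carbonyl carbon), the same change at the same place, a saturated chain carbon bound to a carbonyl carbon. Going by the values given here, for compound 4 in this assay a step of about a 9.0-fold higher number from compound 2 to compound 4 (0.95 log units; beyond the scatter) is expected, resting on the single earlier instance of the change, an 8.9-fold higher number from compound 1 to compound 3 (0.95 log units; beyond the scatter), carried over onto the core of compound 2. Among the compounds with values here, only one prior example exists, so the expectation is loose and the range is kept wide. Compound 4 is therefore estimated at 9 nM, between 3 nM and 27 nM.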

Compound 4, inhibition constant: 34 nM
The estimate for compound 4 lay 3.8-fold (0.58 log units) below the measured number; the whole stated range lies below it.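

In this assay, hydrogen in place of ethyl on a saturated chain carbon bound to a carbonyl carbon again gives a weaker inhibitor, here with a 34-fold higher number from compound 2 to compound 4 (1.53 log units; beyond the scatter). The direction of the change carries over from one core to the other, but its size does not: the same change on two cores in this assay, an 8.9-fold higher number (0.95 log units; beyond the scatter) from compound 1 to compound 3 and a 34-fold higher number (1.53 log units; beyond the scatter) from compound 2 to compound 4, 3.8-fold (0.58 log units) apart, beyond the scatter of two such steps

These two pairs show that a step measured on one core is a poor guide to the size of the same step on the other, but they do not show which feature of the cores sets the size, or how the change would behave on any further core.

As far as these compounds go, only ethyl and hydrogen appear at this place, so it remains open how the number would move on either core with a methyl group or a longer chain such as propyl or butyl. Also open, from the compounds shown here alone, is whether a cyclopropyl group at the same place would follow the same course on both cores or again give steps of different size.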